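Dimethylamino in place of fluoro: an estimate

The source may report more compounds than this note shows. Statements on the series, on what has been measured and on what is new or still open speak of the compounds shown alone.

Compound 1 `Cc1ccc2[nH]c(-c3ccc(-c4ccc(-c5cccc(Cl)c5)cc4)cc3)nc2c1` gives 2800 nM in a functional assay on A549 cells (Homo sapiens) for inhibition, read by sulforhodamine B assay; a higher number here means a weaker inhibitor of growth, a lower number a stronger inhibitor of growth
Compound 2 `Fc1ccc(-c2ccc(-c3ccc(-c4nc5ccccc5[nH]4)cc3)cc2)cc1` gives 33200 nM in this assay

Compound 2 stands highest of the two, making it the weaker growth inhibitor, and the gap to compound 1 lies beyond the scatter. Compound 3 `CN(C)c1ccc(-c2ccc(-c3ccc(-c4nc5ccccc5[nH]4)cc3)cc2)cc1` differs from compound 2 by dimethylamino in place of fluoro on an aromatic carbon with dimethylamino in place of fluoro on an aromatic carbon. Among the measured compounds shown here, no measured pair shows this change, so the expectation is only a judgement: a moderate move toward a lower number in this assay with the expected step of a 2.8-fold lower number from compound 2 to compound 3 (0.44 log units; beyond the scatter) as its size. The estimated value for compound 3 is 12000 nM (expected range 3500 nM to 40000 nM).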

Compound 3, concentration for 50% growth inhibition: 30100 nM
Compound 3: the middle estimate sits 2.5-fold (0.40 log units) below what was measured, and the stated range covers the measured number.
By their numbers in this assay, from the lowest: compound 1; then compounds 3 and 2 (each within the scatter of the next).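

Dimethylamino in place of fluoro on this aromatic carbon, para to a large group, gives a 1.1-fold lower number from compound 2 to compound 3 (0.04 log units; within the scatter) in this assay. Among the compounds shown here, this is the first one-place comparison, and it shows that two groups differing in heavy-atom count and hydrogen-bond acceptors read alike at this position. No evidence at hand accounts for this result. On these data alone, whether a carboxylic acid or a longer amine chain at this position would separate from these two remains open, as does whether the same swap would read alike on the core of compound 1.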